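The compounds below may be only part of what the source reports. "The series", "measured", "known", "first", "only" and "open" are said of these compounds alone.

Of the compounds shown here, three built on one shared core have been tested so far. Compound 1 `Nc1ccccc1NC(=O)c1ccc(CSC(=S)N2CCN(Cc3ccccn3)CC2)cc1` carries a (pyridin-2-yl)methyl group on an amine nitrogen in a ring, and in a functional assay on A-375 cells (Homo sapiens) for antiproliferative activity, read by CCK-8 assay, with a stated time of 72 h, tested at 8 uM (on this read-out lower numbers stand for a weaker effect and higher numbers for a stronger effect at the one concentration tested), compound 1 gives 82.4%. Compound 2 `Nc1ccccc1NC(=O)c1ccc(CSC(=S)N2CCN(c3ccccc3)CC2)cc1` has a phenyl there instead; in this assay compound 2 gives 88.6%. Going by the values given here, the only measured step, a number 6.2 percentage points higher from compound 1 to compound 2 (within the scatter), lies within the usual scatter and so shows no real difference. Compound 3 `Nc1ccccc1NC(=O)c1ccc(CSC(=S)N2CCc3ccccc32)cc1` has a 2,3-dihydro-1H-indol-1-yl group in that position; in this assay compound 3 gives 85.4%, a number that sits between those of compound 1 and compound 2, with both gaps inside the scatter.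

Compound 4 `Nc1ccccc1NC(=O)c1ccc(CSC(=S)N2CCc3cc(Cl)ccc32)cc1` differs from compound 3 by chloro in place of hydrogen on an aromatic carbon; cut one bond further out, the change reads 2,3-dihydro-1H-indol-1-yl to 5-chloro-2,3-dihydro-1H-indol-1-yl. Among the compounds with values here, no measured step adds a chloro to any ring, and the single step that was measured stayed inside the scatter, so nothing points to a shift in either direction. The expected step, a number 0.4 percentage points lower from compound 3 to compound 4 (within the scatter), is therefore none beyond the scatter. Compound 4 is estimated to give 85% in this assay, within a range from 74% to 94%, because compound 3 gives 85.4%.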

Compound 4, a percentage reported as inhibition, at one concentration (the size of the read-out at that concentration, not a potency): 82.3%
For compound 4 the middle estimate is 2.7 percentage points above the measured one; the range from low to high includes it.
By their numbers in this assay, from the lowest: compounds 4, 1, 3 and 2 (each within the scatter of the next).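

Going by these compounds alone, the 2,3-dihydro-1H-indol-1-yl group of compound 3 is the first place in this set where a substituent was added to an aromatic ring, and this change can now be judged directly. In this assay, chloro in place of hydrogen on an aromatic carbon gives a number 3.1 percentage points lower from compound 3 to compound 4 (within the scatter), so the read-out shows no real difference and this position accepts a chloro without a measurable loss or gain at the one concentration tested. Nothing available explains this outcome.

As far as these compounds go, whether a different group here, such as methoxy, an amine or a carboxylic acid, would move the number beyond the scatter remains open. Also open, from the compounds shown here alone, is whether these compounds differ in potency, since a read-out at one concentration does not give a potency.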